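Working notes: swapping the group on the aromatic nitrogen

The source may report more compounds than this note shows. Statements on the series, on what has been measured and on what is new or still open speak of the compounds shown alone.

- compound 1 `C=CCc1ccc(OCc2cn(-c3ccc(OC)cc3)nn2)c(O)c1` gives 38.9%
- compound 2 `C=CCc1ccc(OCc2cn(-c3ccccc3CO)nn2)c(O)c1` gives 47.1%

Both values come from a functional assay on HL-60 cells (Homo sapiens) for inhibition, read by MTT assay, with a stated time of 72 h, tested at 50 uM; on this read-out higher numbers stand for more inhibition of growth at the one concentration tested and lower numbers for less inhibition of growth. In this assay, among the compounds with values here, compound 2 stands at 47.1%, with compound 1 as its only neighbour. Within the data shown here, the one measured step is a number 8.2 percentage points higher from compound 1 to compound 2 (within the scatter), so the two compounds are not separated.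

Compound 3 `C=CCc1ccc(OCc2cn(-c3cccc(C#N)c3)nn2)c(O)c1`, not yet measured, carries 3-cyanophenyl in place of 2-(hydroxymethyl)phenyl on an aromatic nitrogen. Among the measured compounds shown here, only one measured change bears on this, made on the same nitrogen: a number 8.2 percentage points higher from compound 1 to compound 2 (within the scatter). It gives no sign that a swap here moves the number beyond the scatter, and it offers no firm direction. For the measured compounds named here, no measured compound yet carries the nitrile.

The expected change is small, and no step beyond the scatter is anticipated: a number 5.1 percentage points lower from compound 2 to compound 3 (within the scatter). For compound 3 the estimated value is 42%, with an expected range of 28% to 56%.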

Compound 3, percent growth inhibition at one concentration: 30.9%
Beside the measured number, compound 3's estimate is 11.1 percentage points above it; measured number inside the range.
By their numbers in this assay, from the lowest: compounds 3, 1 and 2 (each within the scatter of the next, the first and the last beyond it).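

In this assay, the group on the aromatic nitrogen now gives a step that clears the scatter: 3-cyanophenyl in place of 2-(hydroxymethyl)phenyl gives a number 16.2 percentage points lower from compound 2 to compound 3 (beyond the scatter) in this series. The same group in place of 4-methoxyphenyl gives a number 8 percentage points lower from compound 1 to compound 3 (within the scatter), so these two groups are not separated and only the 2-(hydroxymethyl)phenyl and 3-cyanophenyl compounds stand apart. Nothing available accounts for the larger step.

The compounds shown cannot tell whether that step follows the loss of the hydroxymethyl group, the arrival of the nitrile or the different place of the substituent, since all of these change together. Going by these compounds, how an aminomethyl group or a carboxylic acid on the same phenyl ring would read in this assay also remains open.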